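Cytotoxicity limits in a tertiary-amine quinolinone series

The source may hold more compounds than are shown below. What is called first, only, known or untested is meant among the compounds shown, and "the series" means these compounds.

Measured so far:
Compound 1 `Cc1ccc2[nH]c(=O)c(CN(Cc3ccc(C(N)=O)cc3)Cc3ccc(C(C)(C)C)cc3)cc2c1` in a toxicity assay on MDCK cells (Canis lupus familiaris) for cytotoxicity, read by crystal violet staining, with a stated time of 48 h (a higher number here means that more compound is tolerated, a lower number that less compound is tolerated), gives > 5000 nM, a limit of the assay.
Compound 2 `Cc1ccc2[nH]c(=O)c(CN(Cc3ccc(SC(F)(F)F)cc3)Cc3ccc(C(C)(C)C)cc3)cc2c1` in this assay gives > 5000 nM, also a limit of the assay.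

Compound 2 therefore stands only at a limit in this assay, with no number of its own. The step that the two limits leave unreadable from compound 1 to compound 2 cannot be sized, because of the limit of > 5000 nM in this assay, at which 2 of the 2 values shown sit. Compound 3 `COc1ccc(C(C)N(Cc2ccc(C(C)(C)C)cc2)Cc2cc3cc(C)ccc3[nH]c2=O)cc1` differs from compound 2 by 1-(4-methoxyphenyl)ethyl in place of 4-((trifluoromethyl)sulfanyl)benzyl on an amine nitrogen. No measured step can be read to bear on this change. With both values shown sitting at the limit, compound 3 is expected to give a similar limit in this assay, estimated at 8000 nM within 3000 nM to 30000 nM, which means an expected step that the limit leaves unreadable from compound 2 to compound 3.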

Compound 3, half-maximal cytotoxic concentration: > 5000 nM
Compound 3 ended at the assay's limit; the forecaster's own chance of this, stated with the estimate: 80%; the middle value does not contradict the limit.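

No new step can be read for compound 1, compound 2 or compound 3 in this assay, because all three stand at a limit: the limit of > 5000 nM in this assay, at which 3 of the 3 values shown sit.

The compounds shown leave open whether changing the group on the amine nitrogen alters cytotoxicity at all.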